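This account rests on a few compounds, and the source may have more. Where it says the series, first, only, none or still open, it means among the compounds named here.

The measured compounds:
compound 1, `COC1=C[C@H](O)[C@H](C/C=C(\C)CC/C=C(\C)CCC=C(C)C)[C@@H](C)C1=O`, 16400 nM
compound 2, `COC1=C(OC)[C@H](OC(C)=O)[C@H](C/C=C(\C)CC/C=C(\C)C[C@H](O)/C=C(\C)C(=O)O)[C@@H](C)C1=O`, > 30000 nM

In a functional assay on A549 cells (Homo sapiens) for inhibition, read by sulforhodamine B assay, with a stated time of 48 h (on this read-out lower numbers stand for stronger inhibition of growth and higher numbers for weaker inhibition of growth), compound 1 gives 16400 nM. In this assay compound 2 gives only a limit, > 30000 nM, and not a number. Where compound 2 stands among the numbers shown is therefore told by the limit of > 30000 nM in this assay, at which 1 of the 2 values shown sits, and no step between measured compounds is available to anchor the change that follows.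

Compound 3, `COC1=C(OC)[C@H](OC(C)=O)[C@H](C/C=C(\C)CC/C=C(\C)C[C@@H]2C[C@@H](C)C(=O)O2)[C@@H](C)C1=O`, has yet to be measured in this assay. It differs from compound 2 by a group of 7 heavy atoms (5 carbon, 2 oxygen; one five-membered non-aromatic ring with 1 hetero atom) in place of a group of 8 heavy atoms (5 carbon, 3 oxygen; no ring), on a saturated chain carbon bound to a double-bonded chain carbon. For the measured compounds named here, with no measured step to lean on, the expectation is a move toward stronger inhibition of growth of the size an at least 1.6-fold lower number from compound 2 to compound 3 (0.22 log units; that floor lies within the scatter), though a result that again reaches only the limit would not be surprising. Compound 3 is expected to give 18000 nM, within a range from 5000 nM to 60000 nM.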

Compound 3, concentration for 50% growth inhibition: 11300 nM
Compound 3: the middle estimate sits 1.6-fold (0.20 log units) above what was measured; the range from low to high includes it.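

In this assay, the place on a saturated chain carbon bound to a double-bonded chain carbon now shows a change that can be read: the one five-membered non-aromatic ring with 1 hetero atom, in place of the open-chain group with no ring, gives an at least 2.6-fold lower number from compound 2 to compound 3 (0.42 log units; beyond the scatter). This is the first sign among the compounds shown that the group at this place bears on inhibition of growth. The step is a floor and not a full size because compound 2 gives only a limit: the limit of > 30000 nM in this assay, at which 1 of the 3 values shown sits.

The compounds shown leave open whether the ring itself or the loss of the carboxylic acid goes with the change; a methyl ester or a primary amide on the open chain would separate the two. As far as these compounds go, how large the true step is also remains open.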